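From 3-Aminopropoxy to 6-Fluoropyridin-3-yl on a Shared Core

The compounds below may be only part of what the source reports. "The series", "measured", "known", "first", "only" and "open" are said of these compounds alone.

Compound 2 `COc1cc(OC)c2c(=O)cc(-c3ccc(OCCCN)cc3)oc2c1` gives 22% in a functional assay (Homo sapiens) for antiproliferative activity, read by resazurin assay, with a stated time of 48 h, tested at 5 uM (a higher number here means a stronger effect of the compound at the concentration tested, a lower number a weaker effect), the lower of the two numbers recorded, while compound 1 `COc1cc(OC)c2c(=O)cc(-c3ccc(OCCCN(C)C)cc3)oc2c1` gives 36%. Among the compounds with values here, the only measured step is a number 14 percentage points lower from compound 1 to compound 2 (beyond the scatter), which concerns the end of the chain rather than its replacement. Compound 3 `COc1cc(OC)c2c(=O)cc(-c3ccc(-c4ccc(F)nc4)cc3)oc2c1` differs from compound 2 by 6-fluoropyridin-3-yl in place of 3-aminopropoxy on an aromatic carbon. Within the data shown here, no measured step bears on an exchange of this kind, so neither direction can be read from the numbers, and a wide range is warranted. Compound 3 is therefore expected at 30%, between 5% and 60%, an estimated step of a number 8 percentage points higher from compound 2 to compound 3 (within the scatter).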

Compound 3, a percentage reported as inhibition, at one concentration (the size of the read-out at that concentration, not a potency): "not active" (no number reported)
The entry for compound 3 holds no number; the estimate stays without a comparison.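

Within the data shown here, compound 3 is recorded as not active, without a number, so no step from compound 2 to compound 3 can be read. How far 6-fluoropyridin-3-yl shifts the effect relative to 3-aminopropoxy stays open, and no evidence shown bears on this result.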